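Aryl versus lactam at the sulfonamide end

The source may hold more compounds than are shown below. What is called first, only, known or untested is meant among the compounds shown, and "the series" means these compounds.

Compound 1 `COc1ccc(F)c(-c2ccc(S(=O)(=O)Nc3cc(N4C[C@@H](C)N[C@@H](C)C4)ccc3OC)cc2)c1`: 0.398 nM
Compound 2 `COc1ccc(N2C[C@@H](C)N[C@@H](C)C2)cc1NS(=O)(=O)c1ccc(-c2cc(Cl)ccc2F)cc1`: 0.501 nM
Compound 3 `COc1ccc(N2C[C@@H](C)N[C@@H](C)C2)cc1NS(=O)(=O)c1ccc(N2CCCC2=O)cc1`: 39.8 nM

In a functional assay for agonist activity at growth hormone secretagogue receptor type 1 (Homo sapiens), read by FLIPR (on this read-out higher numbers stand for an effect only at larger amounts of compound and lower numbers for an effect already at smaller amounts), compound 3 gives the highest number of the three. The step of a 100-fold higher number from compound 1 to compound 3 (2.00 log units; beyond the scatter) and the step of a 79-fold higher number from compound 2 to compound 3 (1.90 log units; beyond the scatter) were both large. Compound 4 `COc1ccc(N2C[C@@H](C)N[C@@H](C)C2)cc1NS(=O)(=O)c1ccc(-c2cccs2)cc1` differs from compound 3 by thiophen-2-yl in place of 2-oxopyrrolidin-1-yl on an aromatic carbon. This again places an aromatic ring where compound 3 carries the lactam, so the two large steps just named bear on it, read in the opposite direction. Since thiophen-2-yl is smaller than either substituted phenyl, the return is expected to be somewhat less than complete, and compound 4 is estimated at 1.6 nM, within 0.4 nM to 6 nM, meaning an expected step of a 25-fold lower number from compound 3 to compound 4 (1.40 log units; beyond the scatter).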

Compound 4, half-maximal effective concentration: 3.98 nM
Compound 4: the middle estimate sits 2.5-fold (0.40 log units) below what was measured, within the range that was stated.
By their numbers in this assay, from the lowest: compounds 1 and 2 (each within the scatter of the next); then compound 4; then compound 3.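

Thiophen-2-yl recovers only part of what the lactam loses, with a 10-fold lower number from compound 3 to compound 4 (1.00 log units; beyond the scatter). It still falls short of both substituted phenyl groups, with a 7.9-fold higher number from compound 2 to compound 4 (0.90 log units; beyond the scatter) and a 10-fold higher number from compound 1 to compound 4 (1.00 log units; beyond the scatter). This adds an intermediate level at this position. Both groups are five-membered rings, and ring size alone does not set the number here. Nothing available explains the gap between these groups.

From the compounds shown here alone, it remains open whether an unsubstituted phenyl or a pyridyl ring would stand with thiophen-2-yl or with the substituted phenyl groups. Going by these compounds, it is also open whether a chloro group on the thiophene would close the remaining gap.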